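The source may hold more compounds than are shown below. What is called first, only, known or untested is meant among the compounds shown, and "the series" means these compounds.

Measured so far:
compound 1 `N#CC1=C(N)N(c2ccc(S(N)(=O)=O)cc2)C2=C(CCCC2)C1c1ccc([N+](=O)[O-])cc1`: 5%
compound 2 `N#CC1=C(N)N(c2ccc(S(N)(=O)=O)cc2)C2=C(CCCC2)C1c1ccc(Cl)cc1Cl`: 50%

In a functional assay on Ehrlich cells (Mus musculus) for cytotoxicity, read by trypan blue exclusion, with a stated time of 2 h, tested at 25 ug/mL (a higher number here means a stronger effect of the compound at the concentration tested, a lower number a weaker effect), compound 1 gives 5% and compound 2 gives 50%. Compound 2 stands highest of the two numbers; the nearest is compound 1, and the step of a number 45 percentage points higher from compound 1 to compound 2 (beyond the scatter) is large. Among the compounds with values here, this is the only step measured, and it exchanges one aryl group for another on the same saturated ring carbon, so it is the step that bears on the move to compound 3.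

Compound 3 `N#CC1=C(N)N(c2ccc(S(N)(=O)=O)cc2)C2=C(CCCC2)C1c1c(O)ccc2ccccc12` is not yet measured. It differs from compound 2 by 2-hydroxynaphthalen-1-yl in place of 2,4-dichlorophenyl on a saturated ring carbon. Within the data shown here, nothing measured shows what a 2-hydroxynaphthalen-1-yl does at this position; the one comparable step shows only that the aryl group on this carbon can shift the read-out by a large amount, in either direction as far as the data go. The step of a number 10 percentage points lower from compound 2 to compound 3 (within the scatter) is therefore expected to be small, with a wide range around it. Compound 3 is expected to give 40% in this assay, between 15% and 70%.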

Compound 3, a percentage reported as activity, at one concentration (the size of the read-out at that concentration, not a potency): 5%
Compound 3: middle estimate off by 35 percentage points, on the high side, and the stated range ends above it.
By their numbers in this assay, from the lowest: compounds 1 and 3 (each within the scatter of the next); then compound 2.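

In this assay, the exchange on the saturated ring carbon gives a number 45 percentage points lower from compound 2 to compound 3 (beyond the scatter), so the reading of compound 2 now stands apart from two different aryl groups, 4-nitrophenyl and 2-hydroxynaphthalen-1-yl, instead of one. Exchanging those two groups gives no change at the digits printed from compound 1 to compound 3 (within the scatter), so at this position two groups with different atoms read alike, and of the three aryl groups shown only 2,4-dichlorophenyl stands apart. No measurement at hand accounts for that separation.

Going by these compounds, whether the reading of compound 2 depends on the two chlorine atoms, on where they sit, or on the phenyl ring that carries them stays open, and an unsubstituted phenyl or a 4-chlorophenyl at this carbon would begin to separate these. Also open, on these data alone, is whether the reading of compound 3 depends on its hydroxyl group or on the naphthalene rings, which a plain naphthalen-1-yl would address, and how an aryl group carrying an amine or a carboxylic acid would read at this position.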